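Halogen exchange on the aromatic ring of compound 2

The compounds below may be only part of what the source reports. "The series", "measured", "known", "first", "only" and "open" are said of these compounds alone.

Compound 1 `Cc1nc2sc(-c3ccccc3)nc2c(=O)[nH]1`: 85 nM
Compound 2 `Cc1nc2sc(-c3cccc(Cl)c3)nc2c(=O)[nH]1`: 826 nM

Of the compounds shown here, two of the shared core have been measured in an assay on CHO cells for displacement of a labelled ligand from adenosine receptor A3 (Homo sapiens), read by scintillation counting, with a stated time of 120 min; a higher number here means a weaker inhibitor, a lower number a stronger inhibitor. Compound 1 gives 85 nM, and compound 2 gives 826 nM. Among the compounds with values here, the only step between measured compounds is a 9.7-fold higher number from compound 1 to compound 2 (0.99 log units; beyond the scatter), brought about by chloro in place of hydrogen on an aromatic carbon. Within the data shown here, compound 2 therefore stands with the higher of the two numbers in this assay, its sole neighbour being compound 1 at a lower number.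

Compound 3 `Cc1nc2sc(-c3cccc(F)c3)nc2c(=O)[nH]1` differs from compound 2 by fluoro in place of chloro on an aromatic carbon. Among the measured compounds shown here, no measured step exchanges one halogen for another; the step from compound 1 to compound 2 is the only one bearing on this position, and it was modest. Compound 3 is estimated to land between the two measured compounds, with a step of a 2.8-fold lower number from compound 2 to compound 3 (0.44 log units; beyond the scatter) expected downward in this assay, giving an estimate of 300 nM within a range from 100 nM to 900 nM.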

Compound 3, inhibition constant: 109 nM
Compound 3: middle estimate off by 2.8-fold (0.44 log units), on the high side; low and high end bracket the measured number.
By their numbers in this assay, from the lowest: compounds 1 and 3 (each within the scatter of the next); then compound 2.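

In this assay, fluoro in place of chloro gives a 7.6-fold lower number from compound 2 to compound 3 (0.88 log units; beyond the scatter), so the loss seen with chloro at this place on the aromatic ring is not shared by both halogens. Fluoro in place of hydrogen gives a 1.3-fold higher number from compound 1 to compound 3 (0.11 log units; within the scatter), which means that this position accepts fluoro with no change that can be told from the scatter, and among the three compounds only chloro, in compound 2, goes with a weaker number. No measurement on hand explains why the two halogens part so clearly.

As far as these compounds go, whether a larger halogen such as bromo, or a group such as methyl, methoxy or an amine, would follow fluoro or chloro at this place stays open. So does whether fluoro and chloro would behave the same way elsewhere on this ring.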